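A few compounds are considered here, and "the series" means these few. Any claim that something is new, unique, unknown or untested is made for them only; others in the source may bear on it.

Compound 2 `CCCCNc1nc(CC)nc2c1cnn2-c1ccccc1` was tested in a functional assay on G-361 cells (Homo sapiens) for cytotoxicity, read by sulforhodamine B assay; a lower number here means that less compound is tolerated, a higher number that more compound is tolerated. In this assay compound 2 gives only a limit, > 100000 nM, and not a number. Compound 1 `Cc1nc(NCc2ccco2)c2cnn(-c3ccccc3)c2n1` likewise gives only a limit, > 100000 nM. Both measured values thus sit at the limit of > 100000 nM in this assay, at which 2 of the 2 values shown sit, so compound 2 stands at the edge of what the assay could report, with nothing to separate it from compound 1.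

Compound 3 `CCc1nc(NCc2ccco2)c2cnn(-c3ccccc3)c2n1` has not yet been measured in this assay. It differs from compound 2 in one place: furan-2-yl in place of propyl on a saturated chain carbon bound to a nitrogen on an aromatic ring. Compound 3 thereby carries the same (furan-2-yl)methylamino group as compound 1, whose result also sat at the limit. With both measured compounds at the limit, the step that the limit leaves unreadable from compound 2 to compound 3 is expected to show no change beyond the scatter. Compound 3 is therefore estimated at 150000 nM, within a range from 50000 nM to 500000 nM, most likely again reported only as a limit.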

Compound 3, concentration lethal to 50% of the cells: > 100000 nM
Compound 3 ended at the assay's limit (the forecaster's own chance of this, stated with the estimate: 85%); the middle value is on the limit's open side.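

Compound 3 gives only a limit and not a number, just as compound 1 and compound 2 do, and no step among these compounds can be read. The compounds shown leave open whether any of the changed groups alters how much compound the cells tolerate.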